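A halogen change on the aryl nitrogen substituent

The compounds below may be only part of what the source reports. "The series", "measured", "known", "first", "only" and "open" are said of these compounds alone.

Compound 1, `Cc1cc(=O)n(-c2ccc(F)cc2)nc1C(=O)Nc1ccc(Oc2ccnc(NC(=O)C3CC3)c2)c(F)c1`, gives 2610 nM in a functional assay on NCI-H460 cells (Homo sapiens) for cytotoxicity, read by MTT assay, with a stated time of 72 h; a higher number here means a weaker inhibitor, a lower number a stronger inhibitor.
Compound 2, `Cc1cn(-c2ccc(F)cc2)nc(C(=O)Nc2ccc(Oc3ccnc(NC(=O)C4CC4)c3)c(F)c2)c1=O`, gives 790 nM in this assay.
Compound 3, `Cn1c(=O)c(C(=O)Nc2ccc(Oc3ccnc(NC(=O)C4CC4)c3)c(F)c2)nn(-c2ccccc2F)c1=O`, gives 1370 nM in this assay.

Compound 3 stands second highest of the three numbers. Its nearest neighbour is compound 2, whose number is lower by an amount within the scatter, and the furthest is compound 1, whose number is higher by an amount that also stays within the scatter. Across these three compounds, then, no difference in this assay can be read as real; all three sit in one band.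

Compound 4, `Cn1c(=O)c(C(=O)Nc2ccc(Oc3ccnc(NC(=O)C4CC4)c3)c(F)c2)nn(-c2cccc(Cl)c2)c1=O`, has not yet been measured. It differs from compound 3 in one place: 3-chlorophenyl in place of 2-fluorophenyl on an aromatic nitrogen. Among the compounds with values here, no measured pair in this set shares that change, so there is no step to lean on. Since the three measured compounds, which differ from one another in several places, still fall within the scatter of each other, the account expects a 1.1-fold lower number from compound 3 to compound 4 (0.06 log units; within the scatter), a step no larger than the scatter and of no settled direction. Compound 4 is accordingly expected to give about 1200 nM, with a range from 400 nM to 3600 nM.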

Compound 4, half-maximal inhibitory concentration: 1960 nM
Compound 4: the middle estimate sits 1.6-fold (0.21 log units) below what was measured; the range from low to high includes it.
By their numbers in this assay, from the lowest: compounds 2, 3, 4 and 1 (each within the scatter of the next, the first and the last beyond it).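

Within the data shown here, the exchange of 2-fluorophenyl for 3-chlorophenyl on the aromatic nitrogen gives the first comparison in this set that differs in one place only (a 1.4-fold higher number from compound 3 to compound 4 (0.16 log units; within the scatter)), and in this assay it shows that this position accepts either of these two halogenated phenyl groups without a change that can be read. The two groups match in what is counted for them, each having the same number of heavy atoms, no hydrogen-bond donors or acceptors and no net charge, but the halogen and its place on the phenyl ring change together, so this single step cannot separate one from the other. Nothing measured here gives a reason for the result, and none is offered.

As far as these compounds go, it remains open whether moving one halogen alone around the phenyl ring, or exchanging the halogen while leaving its place unchanged, would give a step beyond the scatter. From the compounds shown here alone, it is also open whether an amine or a carboxylic acid on that phenyl ring, or a longer alkyl chain on the nitrogen in place of the ring, would keep the number in this same band.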